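Changing the side-chain ring on a shared core

A few compounds are considered here, and "the series" means these few. Any claim that something is new, unique, unknown or untested is made for them only; others in the source may bear on it.

Of the compounds shown here, three built on one shared core have been tested in an assay on CHO cells for displacement of a labelled ligand from prostaglandin E2 receptor EP3 subtype (Homo sapiens), read by radioligand binding; a higher number here means a weaker inhibitor, a lower number a stronger inhibitor. Compound 1 `CC(C)C(c1ccc(-c2ccc3cccc(F)c3c2)[nH]c1=O)N1CCCCS1(=O)=O` gives 14 nM, compound 2 `CC(C)C(Cc1ncc[nH]1)c1ccc(-c2ccc3cccc(F)c3c2)[nH]c1=O` gives 11 nM, and compound 3 `CC(C)C(c1ccc(-c2ccc3cccc(F)c3c2)[nH]c1=O)N1CCN/C1=N\C#N` gives 23 nM. Compound 2 holds the lowest number of the three, though the step of a 1.3-fold lower number from compound 1 to compound 2 (0.10 log units; within the scatter) is within the scatter, so these two cannot be ordered, whereas a 2.1-fold higher number from compound 2 to compound 3 (0.32 log units; beyond the scatter) is a modest but genuine separation. All three differ only in the group on a saturated chain carbon bound to an aromatic carbon and a saturated chain carbon. Compound 4 `CC(C)C(/C=C1/CCNC1=O)c1ccc(-c2ccc3cccc(F)c3c2)[nH]c1=O` varies that same place: a group of 7 heavy atoms (5 carbon, 1 nitrogen, 1 oxygen; one five-membered non-aromatic ring with 1 hetero atom) in place of a group of 6 heavy atoms (4 carbon, 2 nitrogen; one five-membered aromatic ring with 2 hetero atoms), on a saturated chain carbon bound to an aromatic carbon and a saturated chain carbon. Within the data shown here, the steps that bear on this exchange are a 1.6-fold higher number from compound 1 to compound 3 (0.22 log units; within the scatter) together with the two just mentioned; every swap so far, whether to an aromatic or a non-aromatic ring, has moved the number only a little. The incoming ring is therefore expected to shift the value modestly at most, with a 1.6-fold higher number from compound 2 to compound 4 (0.21 log units; within the scatter) anticipated. Compound 4 is estimated at 18 nM, within 7 nM to 45 nM.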

Compound 4, inhibition constant: 5.3 nM
The estimate for compound 4 lay 3.4-fold (0.53 log units) above the measured number, and the stated range ends above it.
By their numbers in this assay, from the lowest: compound 4; then compounds 2, 1 and 3 (each within the scatter of the next, the first and the last beyond it).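

In this assay the incoming group brings a 2.1-fold lower number from compound 2 to compound 4 (0.32 log units; beyond the scatter) together with a 2.6-fold lower number from compound 1 to compound 4 (0.42 log units; beyond the scatter) and a 4.3-fold lower number from compound 3 to compound 4 (0.64 log units; beyond the scatter) and so makes compound 4 the strongest of the four, showing that this place can set one compound clearly apart from all the others. A non-aromatic ring alone does not produce this, as compound 1 and compound 3 also carry non-aromatic rings and stay at higher numbers. Nothing measured here speaks to the cause of this gain.

The compounds shown leave open which part of the incoming group matters, the five-membered ring or its double bonds outside aromatic rings. They also leave open whether a group with no ring at all, such as a carboxylic acid or a simple amine, could hold the number this low at the same place.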